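The source may hold more compounds than are shown below. What is called first, only, known or untested is meant among the compounds shown, and "the series" means these compounds.

Of the compounds shown here, two that share one core have been tested in a functional assay on the whole organism for inhibition, with Mus musculus as the target, in the maximal electroshock model, at a dose of 15 mg/kg by the oral route; on this read-out higher numbers stand for a stronger effect at the one dose given and lower numbers for a weaker effect. Compound 1 `CCCCN1C(=O)NC2(CC2(C)C)C1=O` gives 50%. Compound 2 `CC1(C)CC12NC(=O)N(c1ccccc1)C2=O` gives 40%, a number that differs from that of compound 1 only within the usual scatter, so the two stand level on this read-out. Compound 3 `CC1(C)CC12NC(=O)N(c1ccc(F)cc1)C2=O` differs from compound 2 by fluoro in place of hydrogen on an aromatic carbon. Among the compounds with values here, no step between measured compounds is known here, so the expectation for compound 3 rests on this change alone. A step of a number 5 percentage points higher from compound 2 to compound 3 (within the scatter) is expected, nothing beyond the scatter. Compound 3 is estimated to give 45%, in a range from 20% to 70%.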

Compound 3, a percentage reported as inhibition, in the whole organism at one dose (the size of the read-out at that dose, not a potency): 50%
Estimate against measurement, compound 3: 5 percentage points below; low and high end bracket the measured number.
By their numbers in this assay, from the lowest: compounds 2, 1 and 3 (each within the scatter of the next).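

In this assay, fluoro in place of hydrogen on the aromatic carbon para to a large group gives a number 10 percentage points higher from compound 2 to compound 3 (within the scatter). This position therefore accepts a single fluorine atom with the effect at this one dose staying level, though the step says nothing about potency. Nothing here bears on what lies behind this result. Still open, going by these compounds, is whether a different group at this same place, such as methoxy or an amine, would move the read-out beyond the scatter. Also open, on these data alone, is whether fluoro elsewhere on the ring would do so.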